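This account rests on a few compounds, and the source may have more. Where it says the series, first, only, none or still open, it means among the compounds named here.

Going by the values given here, compound 1 `COc1ccc(/C=C/C(=O)c2sc(Nc3ccc(Cl)cc3)nc2C)cc1` is one of three compounds so far tested in a functional assay on NCI-H460 cells (Homo sapiens) for cytotoxicity, read by MTT assay; on this read-out lower numbers stand for stronger inhibition and higher numbers for weaker inhibition. In this assay compound 1 gives > 25000 nM, which is a limit of the assay and not a number. Compound 2 `COc1cc(/C=C/C(=O)c2sc(Nc3ccc(Cl)cc3)nc2C)cc(OC)c1OC`, which carries the trimethoxyphenyl pattern on the same core, gives 22000 nM in this assay. Compound 3 `Cc1cccc(Nc2nc(C)c(C(=O)/C=C/c3ccccc3Cl)s2)c1`, with the chloro group and the methyl group placed differently, gives > 25000 nM in this assay, again a limit and not a number. Compound 1 thus stands at the edge of what this assay can report, together with compound 3, as the limit of > 25000 nM in this assay, at which 2 of the 3 values shown sit, makes plain; only compound 2 returns a figure, and that figure sits close to the same edge.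

Compound 4 `Cc1nc(Nc2ccc(Cl)cc2)sc1C(=O)/C=C/c1ccc(Cl)cc1` has not yet been measured. It differs from compound 1 by chloro in place of methoxy on an aromatic carbon, in words chloro in place of methoxy on an aromatic carbon. Among the compounds with values here, since no pair of measured compounds differs in just one place, there is no measured step to lean on, and the three values together give no sign of strong cytotoxicity anywhere in this set. Compound 4 is therefore expected to give 30000 nM in this assay, within a range from 12000 nM to 80000 nM. This estimate means a step that the limit leaves unreadable from compound 1 to compound 4 that is expected to stay within the usual scatter, with the assay most likely reporting only a limit once more.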

Compound 4, half-maximal inhibitory concentration: > 25000 nM
Compound 4: a limit, no number; the forecaster's own chance of this, stated with the estimate: 70%; the middle value lies beyond the limit too.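

Neither compound 1 nor compound 4 returns a number in this assay, so no step between the two can be read, and the result adds only one more compound at the same edge: the limit of > 25000 nM in this assay, at which 3 of the 4 values shown sit.

The compounds shown leave open where compound 1 and compound 4 truly lie, and whether chloro in place of methoxy changes their cytotoxicity at all.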